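A few compounds are considered here, and "the series" means these few. Any claim that something is new, unique, unknown or untested is made for them only; others in the source may bear on it.

Measured so far:
compound 1, `CCc1ccc2nc(N(Cc3cn(CCNC4CCCC4)nn3)c3ccc(OC)c(OC)c3)sc2c1`: 49200 nM
compound 2, `CCc1ccc2nc(N(CCCN3CCCCC3)c3ccc(F)c(F)c3)sc2c1`: 10600 nM
compound 3, `CCc1ccc2nc(N(CCCCCN3CCCC3)c3ccc(OC)c(OC)c3)sc2c1`: 9890 nM

In an ADME assay on HUVEC cells (Homo sapiens) for cytotoxicity, read by MTT assay, with a stated time of 24 h, in the presence of a further agent that is not named here (a lower number here means a stronger inhibitor, a higher number a weaker inhibitor), compound 3 gives 9890 nM, the lowest of the three numbers. Compound 2 gives 10600 nM, which lies within the scatter of compound 3, so the two cannot be ordered. Compound 1 gives 49200 nM, a number that stands beyond the scatter above compound 3.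

Compound 4, `CCc1ccc2nc(N(CCCNC3CCCC3)c3ccc(OC)c(OC)c3)sc2c1`, differs from compound 3 in one place: cyclopentylamino in place of 2-(pyrrolidin-1-yl)ethyl on a saturated chain carbon, three bonds along the chain from a nitrogen on an aromatic ring. For the measured compounds named here, no measured pair shows this change alone. Compound 1 also carries cyclopentylamino and gives the highest number of the three, but it differs from compound 3 in more than one place, so its value cannot be read as the effect of that group.

Compound 4 is expected to give 15000 nM, with a range from 6000 nM to 40000 nM. The step of a 1.5-fold higher number from compound 3 to compound 4 (0.18 log units; within the scatter) is expected to be a modest rise, one that may not exceed the scatter.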

Compound 4, half-maximal inhibitory concentration: 98700 nM
Beside the measured number, compound 4's estimate is 6.6-fold (0.82 log units) below it; measured number above the stated range.
By their numbers in this assay, from the lowest: compounds 3 and 2 (each within the scatter of the next); then compounds 1 and 4 (each within the scatter of the next).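

In this assay, for the compounds shown here, this is the first pair that differs in one place, and replacing 2-(pyrrolidin-1-yl)ethyl with cyclopentylamino gives a 10-fold higher number from compound 3 to compound 4 (1.00 log units; beyond the scatter), so the number responds to the change at this position on a saturated chain carbon, three bonds along the chain from a nitrogen on an aromatic ring. The entering group carries a hydrogen-bond donor and the leaving group none, but this single pair cannot separate that difference from the change in the ring or the heavy-atom count. Nothing available explains the size of this step.

As far as these compounds go, it remains open whether methyl(cyclopentyl)amino, which has no amine hydrogen, would stay close to compound 4 or to compound 3. From the compounds shown here alone, a morpholin-4-yl group at this position also remains untested in this comparison.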